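The compounds below may be only part of what the source reports. "The series", "measured", "known", "first", "only" and "open" are said of these compounds alone.

Measured so far:
Compound 1 `Cc1ccc(-c2ccc(CSc3nnc(-c4ccc5c(c4)OCCO5)o3)cc2)cn1` gives in a physicochemical assay for solubility, read by HPLC, using the shake flask method (on this read-out lower numbers stand for lower solubility and higher numbers for higher solubility), the value < 1000 nM, which is a limit of the assay rather than a number.
Compound 2 `N#Cc1ccc(-c2ccc(CSc3nnc(-c4ccc5c(c4)OCCO5)o3)cc2)nc1` gives in this assay the value 181000 nM.

Among the compounds with values here, compound 2 therefore holds the only actual number in this assay, since the other reading is a limit (the limit of < 1000 nM in this assay, at which 1 of the 2 values shown sits). Within the data shown here, the single measured step, an at least 180-fold higher number from compound 1 to compound 2 (2.25 log units; beyond the scatter), belongs to the exchange of a methyl-bearing pyridine ring for a nitrile-bearing one. Compound 3 `N#Cc1ccc(-c2ccc(CSc3nnc(-c4ccc5c(c4)OCCO5)o3)cc2)cn1` differs from compound 2 by 6-cyanopyridin-3-yl in place of 5-cyanopyridin-2-yl on an aromatic carbon; the nitrile-bearing pyridine is kept, and only the arrangement of its atoms changes. Among the measured compounds shown here, no measured step rearranges atoms within a nitrile-bearing pyridine, so the large step from compound 1 to compound 2 bears only loosely here. For compound 3 the expected change is a 1.8-fold lower number from compound 2 to compound 3 (0.26 log units; within the scatter), a step that is expected to stay within the scatter or to be a mild decrease. Compound 3 is estimated at 100000 nM, between 30000 nM and 300000 nM.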

Compound 3, solubility: 50000 nM
Compound 3: the middle estimate sits 2.0-fold (0.30 log units) above what was measured, within the range that was stated.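

In this assay, the arrangement of atoms within the nitrile-bearing pyridine matters on its own: a 3.6-fold lower number from compound 2 to compound 3 (0.56 log units; beyond the scatter), even though the two groups have the same atoms and the same counts. Exchanging only methyl for cyano on an aromatic carbon, with the rest of the pyridine and the shared core unchanged, gives an at least 50-fold higher number from compound 1 to compound 3 (1.69 log units; beyond the scatter), so this exchange still gives a large step without the rearrangement that also came with the earlier step. Compound 1 stands at a limit and not at a number: the limit of < 1000 nM in this assay, at which 1 of the 3 values shown sits.

On these data alone, what an amine, a carboxylic acid or a longer chain would give in place of the nitrile on this pyridine remains open. Also open, as far as these compounds go, is why the two arrangements read differently, and how any other arrangement of the nitrile-bearing pyridine would compare with compound 2 and compound 3.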